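Replacing an acetamido group with hydroxy on the outer ring

The source may report more compounds than this note shows. Statements on the series, on what has been measured and on what is new or still open speak of the compounds shown alone.

Of the compounds shown here, three sharing one core have been measured in a functional assay for antagonist activity at thromboxane A2 receptor (Rattus norvegicus); on this read-out higher numbers stand for weaker binding and lower numbers for tighter binding. Compound 1 `O=C(O)CC/C=C\CO[C@H]1C(OCc2ccc(-c3ccccc3)cc2)CC[C@@H]1N1CCCCCC1` gives 25.1 nM. Compound 2 `O=C(O)CC/C=C\CO[C@H]1C(OCc2ccc(-c3ccccc3CCO)cc2)CC[C@@H]1N1CCCCCC1`, which carries a 2-hydroxyethyl group in place of hydrogen on an aromatic carbon, gives 31.6 nM, and the step of a 1.3-fold higher number from compound 1 to compound 2 (0.10 log units; within the scatter) is within the scatter. Compound 3 `CC(=O)NCc1ccc(-c2ccc(COC3CC[C@H](N4CCCCCC4)[C@H]3OC/C=C\CCC(=O)O)cc2)cc1`, with acetamidomethyl in place of hydrogen on an aromatic carbon, gives 20 nM; its number is the lowest of the three, but the step of a 1.3-fold lower number from compound 1 to compound 3 (0.10 log units; within the scatter) and the step of a 1.6-fold lower number from compound 2 to compound 3 (0.20 log units; within the scatter) both lie within the scatter, so no ordering can be read from these values.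

Compound 4 `O=C(O)CC/C=C\CO[C@H]1C(OCc2ccc(-c3ccc(CO)cc3)cc2)CC[C@@H]1N1CCCCCC1` differs from compound 3 by hydroxy in place of acetamido on a saturated chain carbon bound to an aromatic carbon. Every step seen so far on this outer ring, whether adding a hydroxyethyl group, adding an acetamidomethyl group, or exchanging one for the other, stayed within the scatter of this assay. The change to compound 4 again alters only the substituent on that ring, so a step no larger than the scatter is expected, with no clear direction. The expected step is a 1.1-fold higher number from compound 3 to compound 4 (0.04 log units; within the scatter). Compound 4 is therefore estimated at 22 nM, with a range from 9 nM to 55 nM.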

Compound 4, dissociation constant: 20 nM
For compound 4 the middle estimate is 1.1-fold (0.04 log units) above the measured one; the measured number falls inside the stated range.
By their numbers in this assay, from the lowest: compounds 3, 4, 1 and 2 (each within the scatter of the next).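

In this assay, exchanging the acetamido group (four heavy atoms) for a hydroxy group (one heavy atom) on a saturated chain carbon bound to an aromatic carbon gives no change at the digits printed from compound 3 to compound 4 (within the scatter), so in this pair the read-out does not depend on keeping the amide carbonyl and nitrogen. The step from a bare outer ring to hydroxymethyl, a 1.3-fold lower number from compound 1 to compound 4 (0.10 log units; within the scatter), and the exchange of 2-(2-hydroxyethyl)phenyl for 4-(hydroxymethyl)phenyl, a 1.6-fold lower number from compound 2 to compound 4 (0.20 log units; within the scatter), also stay within the scatter, which means that all four outer-ring variants shown so far cannot be told apart in this assay. No separate measurement is available to explain this result.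

On these data alone, what remains open is whether any group at this place can move the number beyond the scatter, for example an aminomethyl group, a carboxymethyl group bearing a carboxylic acid, or a longer chain ending in hydroxy. The values shown also come from this single assay, so whether hydroxymethyl and acetamidomethyl would remain indistinguishable in any other test stays unanswered.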